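From an Amino Ester to a Tosylate on One Core

The source may report more compounds than this note shows. Statements on the series, on what has been measured and on what is new or still open speak of the compounds shown alone.

Three compounds sharing a core have been examined in a functional assay on HCT-116 cells (Homo sapiens) for cytotoxicity, read by MTT assay, with a stated time of 72 h; on this read-out lower numbers stand for stronger inhibition and higher numbers for weaker inhibition. Compound 1 `N[C@H]1CC[C@H](Nc2c(C(=O)NCc3ccc(F)cc3)nc(N3CCCCC3)c3cccnc23)CC1` gives 8500 nM in this assay. Compound 2 `O=C(NCc1ccc(F)cc1)c1nc(NCCO)c2cccnc2c1O` has no result in this assay: "not determined" (no result reported). Compound 3 `COC(=O)CNc1c(C(=O)NCc2ccc(F)cc2)nc(Br)c2cccnc12` reaches only a limit in this assay, > 10000 nM, so its potency is not given as a number. Compound 3 therefore stands at the weak end of what is shown, sitting at the limit of > 10000 nM in this assay, at which 1 of the 3 values shown sits, while compound 1 alone yields a number. Compound 4 `Cc1ccc(S(=O)(=O)Oc2c(C(=O)NCc3ccc(F)cc3)nc(Br)c3cccnc23)cc1` is not yet measured. It differs from compound 3 in one place: ((4-methylphenyl)sulfonyl)oxy in place of ((methoxycarbonyl)methyl)amino on an aromatic carbon. Among the compounds with values here, no step between two measured compounds is known here, so the size of this change cannot be drawn from a precedent. The expected step is a step that the limit leaves unreadable from compound 3 to compound 4, judged to lie within the scatter rather than beyond it. Compound 4 is thus estimated at 12000 nM, with a range from 3000 nM to 40000 nM, and a fair chance that this assay again reports only a limit.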

Compound 4, half-maximal inhibitory concentration: > 20000 nM
Compound 4 gave a limit, no number (the forecaster's own chance of this, stated with the estimate: 60%); at least 1.6-fold (0.22 log units) between middle value and limit.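

Within the data shown here, compound 3 and compound 4 each reach only a limit in this assay, so no step between them can be read. The compounds shown leave open whether ((4-methylphenyl)sulfonyl)oxy in place of ((methoxycarbonyl)methyl)amino on an aromatic carbon changes potency at all, and in which direction.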